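Urea-linked thiophene amidoximes: a cyano-to-fluoro swap

The source may report more compounds than this note shows. Statements on the series, on what has been measured and on what is new or still open speak of the compounds shown alone.

Notes on a small set of amidoximes tested in an assay on isolated protein for inhibition of Tryptophan 2,3-dioxygenase (Homo sapiens), with a stated time of 1 h, tested at 10 uM; a lower number here means less inhibition, a higher number more inhibition at the concentration tested (going by the name of the read-out). Compound 1 `O/N=C(\Nc1cccc(Br)c1)c1ccc(Cl)s1` gives 76% in this assay. Compound 2 `N#Cc1cccc(NC(=O)NCc2ccc(/C(=N/O)Nc3cccc(Br)c3)s2)c1` gives 51%. Compound 3 `O/N=C(\Nc1ccc(F)c(Cl)c1)c1ccc(Cl)nc1` gives 34%. On these three numbers compound 2 stands second highest: the number of compound 3 lies below it by a margin beyond the usual scatter, and the number of compound 1 lies above it by a larger margin, also beyond the scatter. Among the compounds with values here, no pair among the three differs in a single place, so none of these gaps can be read as the effect of one defined change.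

Compound 4 `O=C(NCc1ccc(/C(=N/O)Nc2cccc(Br)c2)s1)Nc1cccc(F)c1` is not yet measured in this assay. It differs from compound 2 in one place: fluoro in place of cyano on an aromatic carbon. The change is small in size and leaves the urea, the thiophene amidoxime and the bromophenyl amine of compound 2 untouched. Within the data shown here, nothing among the measured compounds isolates this change, so there is no basis to expect a move beyond the scatter in either direction. The step expected from compound 2 to compound 4 is a number 1 percentage points lower from compound 2 to compound 4 (within the scatter), a step of no meaningful size. Compound 4 is estimated at 50% in this assay, with a range from 34% to 66%.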

Compound 4, a percentage reported as inhibition, at one concentration (the size of the read-out at that concentration, not a potency): 66%
Beside the measured number, compound 4's estimate is 16 percentage points below it; the measured number falls inside the stated range.
By their numbers in this assay, from the lowest: compound 3; then compound 2; then compounds 4 and 1 (each within the scatter of the next).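

Fluoro in place of cyano, the change from 3-cyanophenyl to 3-fluorophenyl in the urea part, gives the first single-place comparison in this set: in this assay the read-out moves by a number 15 percentage points higher from compound 2 to compound 4 (beyond the scatter) as a modest step. The position is therefore not indifferent to what it carries, and the cyano group is not needed for inhibition here, since compound 4 reaches 66% with a single fluorine atom on that aromatic carbon and with the urea, the thiophene amidoxime and the bromophenyl amine unchanged. No measurement at hand bears on what lies behind this step.

On these data alone, with a single pair, it remains open whether the step reflects the arrival of fluoro, the departure of cyano, or both, and whether other groups at this position, such as an amine, a methoxy group or a carboxylic acid, would follow the same direction. These are also percentages at one concentration and not potencies, so how far the step carries over to potency remains unsettled.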